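This account rests on a few compounds, and the source may have more. Where it says the series, first, only, none or still open, it means among the compounds named here.

Three compounds carry the shared core of compound 2 `CN(C)c1ccc(C2CC(c3ccc(-n4ccnc4)cc3)=NN2)cc1`. In a functional assay on MDA-MB-231 cells (Homo sapiens) for inhibition, read by sulforhodamine B assay, tested at 10 uM (on this read-out higher numbers stand for more inhibition at the one concentration tested (going by the name of the read-out) and lower numbers for less inhibition), compound 2 gives 7.6%, the second highest of the three numbers. Compound 1 `CN(C)c1ccc(C2CC(c3ccc(-n4cncn4)cc3)=NN2)cc1` gives 7% in this assay, and compound 3 `CN1CCN(c2ccc(C3=NN(S(=O)(=O)c4ccc(C(F)(F)F)cc4)C(c4ccc(N(C)C)cc4)C3)cc2)CC1` gives 12.1%, so compound 2 sits within the scatter of both neighbours.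

Compound 4 `CN(C)c1ccc(C2CC(c3ccc(-n4ccnc4)cc3)=NN2S(=O)(=O)c2ccc([N+](=O)[O-])cc2)cc1` has not been measured in this assay. It differs from compound 2 in one place: (4-nitrophenyl)sulfonyl in place of hydrogen on an amine nitrogen in a ring.

For the measured compounds named here, only one measured step is available, and it is a number 0.6 percentage points higher from compound 1 to compound 2 (within the scatter), which concerns the five-membered aromatic ring on the aryl group and not the ring nitrogen where the change to compound 4 takes place. Going by the values given here, no measured pair isolates the entry of a sulfonyl group on that nitrogen. Compound 3 does carry a sulfonyl group on the ring nitrogen, but it also bears a different amine on the other aryl ring, so its value and that of compound 2 can only be set side by side: they lie within the scatter of each other. The expected step from compound 2 to compound 4 is therefore a number 3.4 percentage points higher from compound 2 to compound 4 (within the scatter), no change beyond the scatter in either direction. For compound 4 in this assay the estimate is 11%, with a range from 2% to 25%.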

Compound 4, a percentage reported as inhibition, at one concentration (the size of the read-out at that concentration, not a potency): 41.5%
The estimate for compound 4 lay 30.5 percentage points below the measured number; measured number outside the range, above it.
By their numbers in this assay, from the lowest: compounds 1, 2 and 3 (each within the scatter of the next); then compound 4.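

Placing (4-nitrophenyl)sulfonyl in place of hydrogen on the amine nitrogen in a ring gives, in this assay, a number 33.9 percentage points higher from compound 2 to compound 4 (beyond the scatter) and makes this nitrogen the first position in the series where a single change carries the read-out beyond the scatter. For the compounds shown here, the only earlier step, a number 0.6 percentage points higher from compound 1 to compound 2 (within the scatter) at the five-membered aromatic ring on the aryl group, did not show that any single change could do this. Nothing available explains why this change produces so large a step.

The compounds shown leave open whether the step belongs to the sulfonyl link, to the aromatic ring it carries, or to the nitro group on that ring, and an acetyl group on the same nitrogen or an amine in place of the nitro group would help to separate these parts. They also leave open how the step would look across a range of concentrations, since the read-out comes from one concentration and gives no potency.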